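Decyl in place of 4-methoxyphenyl on the shared core

A few compounds are considered here, and "the series" means these few. Any claim that something is new, unique, unknown or untested is made for them only; others in the source may bear on it.

Measured compounds:
compound 1 `COc1ccc(-c2cn(C[C@H](O)[C@H]3OC(=O)C(OCc4ccccc4)=C3OCc3ccccc3)nn2)cc1`: > 100000 nM
compound 2 `O=C1O[C@H]([C@@H](O)Cn2cc(-c3cc(C(F)(F)F)cc(C(F)(F)F)c3)nn2)C(OCc2ccccc2)=C1OCc1ccccc1`: 57200 nM

In a functional assay on HCT-116 cells (Homo sapiens) for antiproliferative activity, read by MTT assay, with a stated time of 72 h (on this read-out higher numbers stand for weaker inhibition and lower numbers for stronger inhibition), compound 1 gives > 100000 nM, which is a limit of the assay and not a number. Compound 1 therefore sits at the limit of > 100000 nM in this assay, at which 1 of the 2 values shown sits. In this assay compound 2 gives 57200 nM.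

Compound 3 `CCCCCCCCCCc1cn(C[C@H](O)[C@H]2OC(=O)C(OCc3ccccc3)=C2OCc2ccccc2)nn1` is not yet measured. It differs from compound 1 by decyl in place of 4-methoxyphenyl on an aromatic carbon. Among the compounds with values here, no measured pair with a single change is available, so the size of this step is open; a step toward stronger inhibition, beyond the usual scatter, is expected but uncertain. Compound 3 is estimated at 40000 nM (range 10000 nM to 150000 nM). That estimate implies an expected step of an at least 2.5-fold lower number from compound 1 to compound 3 (0.39 log units; beyond the scatter).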

Compound 3, half-maximal inhibitory concentration: 28800 nM
For compound 3 the middle estimate is 1.4-fold (0.14 log units) above the measured one; the measured number falls inside the stated range.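

On the aromatic carbon of the five-membered aromatic ring with 3 nitrogen, an open decyl chain can replace the 4-methoxyphenyl ring without loss of activity: this assay shows an at least 3.4-fold lower number from compound 1 to compound 3 (0.54 log units; beyond the scatter). For this pair, a measurable value at this position does not depend on an aromatic ring. The step gives only a minimum size, as the value of compound 1 is a limit of the assay: the limit of > 100000 nM in this assay, at which 1 of the 3 values shown sits.

As far as these compounds go, whether a shorter chain such as hexyl would retain this gain remains open. So does the effect of an amine or a carboxylic acid at the end of the decyl chain.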